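Nitro in Place of Methoxy: What to Expect for Compound 4

A few compounds are considered here, and "the series" means these few. Any claim that something is new, unique, unknown or untested is made for them only; others in the source may bear on it.

Three measured compounds share one core. In an assay on isolated protein for inhibition of Indoleamine 2,3-dioxygenase 1 (Homo sapiens), read by spectrophotometry (on this read-out lower numbers stand for stronger inhibition and higher numbers for weaker inhibition), compound 2 `COc1ccc2[nH]c(C(=O)Cc3cccnc3)cc2c1` gives 49000 nM, the smaller of the two numbers reported. Compound 3 `COc1ccc2[nH]c(C(=O)Cc3cccnc3)cc2c1O` gives 63000 nM in this assay; the step of a 1.3-fold higher number from compound 2 to compound 3 (0.11 log units; within the scatter) stays within the scatter, so the two cannot be told apart. Compound 1 `COc1ccc2[nH]c(C(=O)Cc3cccnc3)cc2c1OCc1ccccc1` is reported as "not active" (no number reported) in this assay, with no number given. Compound 4 `O=C(Cc1cccnc1)c1cc2cc([N+](=O)[O-])ccc2[nH]1` awaits measurement; it differs from compound 2 as follows: nitro in place of methoxy on an aromatic carbon. Going by the values given here, no measured step involves a nitro or a methoxy, and the only step seen, hydroxy for hydrogen, stayed within the scatter, so the data give no direction for this change. Compound 4 is therefore expected to give about 45000 nM, within the range 10000 nM to 150000 nM. The expected step of a 1.1-fold lower number from compound 2 to compound 4 (0.04 log units; within the scatter) is accordingly no larger than the scatter.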

Compound 4, half-maximal inhibitory concentration: "not active" (no number reported)
For compound 4 the study gives words and no number; there is nothing to compare the estimate with.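

In this assay, going by these compounds alone, compound 4 stands as "not active" (no number reported) and so no step from compound 2 to compound 4 can be read. Nothing shown explains this result. The compounds shown leave open how much weaker compound 4 is than compound 2, if it has any measurable inhibition at all.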